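Methyl for Chloro on the Sulfonyl Aryl Ring

A few compounds are considered here, and "the series" means these few. Any claim that something is new, unique, unknown or untested is made for them only; others in the source may bear on it.

Compound 3 `O=S(=O)(NCCCNc1nccc(-c2c(-c3cccc(F)c3)nc3sccn23)n1)c1ccc(Cl)cc1` gives 5900 nM in a functional assay on A-375 cells (Homo sapiens) for cytotoxicity, read by MTT assay (a higher number here means a weaker inhibitor, a lower number a stronger inhibitor), the lowest of the three measured values: compound 1 `O=S(=O)(NCCCNc1nccc(-c2c(-c3cccc(F)c3)nc3sccn23)n1)c1cccc(F)c1` gives 13700 nM and compound 2 `O=S(=O)(NCCNc1nccc(-c2c(-c3cccc(F)c3)nc3sccn23)n1)c1ccc(Br)cc1` gives 13500 nM. The steps of a 2.3-fold lower number from compound 1 to compound 3 (0.37 log units; beyond the scatter) and a 2.3-fold lower number from compound 2 to compound 3 (0.36 log units; beyond the scatter) both exceed the scatter, whereas a 1.0-fold lower number from compound 1 to compound 2 (0.01 log units; within the scatter) does not. Compound 4 `Cc1ccc(S(=O)(=O)NCCCNc2nccc(-c3c(-c4cccc(F)c4)nc4sccn34)n2)cc1` differs from compound 3 by methyl in place of chloro on an aromatic carbon. Among the compounds with values here, no measured step exchanges chloro for methyl; the two steps reaching compound 3 changed the halogen on the phenyl ring and, in one case, the chain, each by a modest amount. A change in this assay no larger than those is therefore expected, possibly within the scatter, estimated as a 1.3-fold higher number from compound 3 to compound 4 (0.10 log units; within the scatter). Compound 4 is expected to give 7500 nM in this assay, between 3500 nM and 16000 nM.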

Compound 4, half-maximal inhibitory concentration: 8380 nM
Beside the measured number, compound 4's estimate is 1.1-fold (0.05 log units) below it; the range from low to high includes it.
By their numbers in this assay, from the lowest: compounds 3, 4, 2 and 1 (each within the scatter of the next, the first and the last beyond it).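

At this position, para to a large group, methyl in place of chloro gives a step within the scatter in this assay: a 1.4-fold higher number from compound 3 to compound 4 (0.15 log units; within the scatter). Compound 3 stood beyond the scatter of compound 1 and compound 2, but the methyl compound does not, with a 1.6-fold lower number from compound 2 to compound 4 (0.21 log units; within the scatter) and a 1.6-fold lower number from compound 1 to compound 4 (0.21 log units; within the scatter). No measurement available here bears on the reason for these results. On these data alone, whether an amine, a carboxylic acid or a methoxy group at this position would give a step beyond the scatter remains open.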